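Dropping the trifluoromethyl from a benzoxazole sulfonamide

The compounds below may be only part of what the source reports. "The series", "measured", "known", "first", "only" and "open" are said of these compounds alone.

The measured compounds:
- compound 1, `O=S(=O)(Nc1ccc(-c2nc3ccccc3o2)cc1)c1ccc(Cl)c(C(F)(F)F)c1`, 12000 nM
- compound 2, `O=S(=O)(Nc1ccc(-c2nc3ccccc3o2)cc1)c1ccc(F)c(C(F)(F)F)c1`, 28000 nM
- compound 3, `CCc1ccc(S(=O)(=O)Nc2ccc3oc(-c4ccccc4)nc3c2)cc1`, > 100000 nM

Three compounds sharing a benzoxazole-bearing sulfonamide were tested in an assay on cells for inhibition of HSP60/HSP10 (Homo sapiens), with a stated time of 60 min; on this read-out lower numbers stand for stronger inhibition and higher numbers for weaker inhibition. Compound 1 gave 12000 nM. Compound 2, which carries fluoro in place of chloro on an aromatic carbon, gave 28000 nM; this is the higher of the two numbers shown, with compound 1 its nearest neighbour at a 2.3-fold higher number from compound 1 to compound 2 (0.37 log units; beyond the scatter). For compound 3 the assay reported only a limit, > 100000 nM, and no number (the limit of > 100000 nM in this assay, at which 1 of the 3 values shown sits).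

The step of interest leads from compound 2 to compound 4, `O=S(=O)(Nc1ccc(-c2nc3ccccc3o2)cc1)c1ccc(F)cc1`, whose structure differs as follows: hydrogen in place of trifluoromethyl on an aromatic carbon. Within the data shown here, none of the measured steps covers this change; the only measured step, a 2.3-fold higher number from compound 1 to compound 2 (0.37 log units; beyond the scatter), concerns a halogen swap and bears on it only indirectly, in showing that a small change on that ring moves the number modestly. With the substituent pattern on the sulfonyl-bearing ring thinned out, compound 4 is expected to give a higher number in this assay, a step of a 2.1-fold higher number from compound 2 to compound 4 (0.33 log units; beyond the scatter), though with considerable uncertainty. The estimate for compound 4 is 60000 nM, with a range from 20000 nM to 150000 nM.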

Compound 4, half-maximal inhibitory concentration: 73000 nM
For compound 4 the middle estimate is 1.2-fold (0.09 log units) below the measured one, and the stated range covers the measured number.
By their numbers in this assay, from the lowest: compound 1; then compound 2; then compound 4. At a limit, above all of these: compound 3.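

Among these compounds, replacing the trifluoromethyl with hydrogen, on the aromatic carbon ortho to a fluoro group, gives a 2.6-fold higher number from compound 2 to compound 4 (0.42 log units; beyond the scatter), which shows for the first time that this position responds to the loss of a group and not only to a change of halogen elsewhere on the ring. The step is modest for the removal of a whole trifluoromethyl, and in this assay compound 4 still gives a number, 73000 nM, so this group is not required for a measurable read-out on this core. Compound 3, which has a different substitution pattern and cannot be compared directly, remains a limit and not a number: the limit of > 100000 nM in this assay, at which 1 of the 4 values shown sits.

The compounds shown leave open whether a methyl, a methoxy or an amine on this same carbon would give a number nearer that of compound 2 or that of compound 4. They also leave open whether chloro in place of fluoro would still lower the number once the trifluoromethyl is gone, so it cannot be told whether the two changes act independently.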